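Amide substituent exchange on a fluorophenyl alkyne scaffold

This account rests on a few compounds, and the source may have more. Where it says the series, first, only, none or still open, it means among the compounds named here.

The three measured compounds share a core and differ at the aryl alkyne or at the amide substituent. Compound 1 `C[C@@H](NC(=O)c1ccc(C#Cc2ccc(F)cn2)cn1)C(C)(C)O` gives 13.5% in an ADME assay on HEK293 cells for agonist activity at metabotropic glutamate receptor 5 (Rattus norvegicus), read by fluorescence and calcium flux; a higher number here means a larger maximal response, a lower number a smaller maximal response; compound 2 `C[C@@H](NC(=O)c1ccc(C#Cc2cc(F)ccn2)cn1)C(C)(C)O` gives 33%; compound 3 `C[C@@H](NC(=O)c1ccc(C#Cc2cccc(F)c2)cn1)C(C)(C)C` gives 31.2%. On these numbers compound 3 stands second highest of three: its value and that of compound 2 lie within the scatter of each other, while compound 1 sits lower by a margin beyond the scatter. Going by the values given here, the only step between measured compounds, a number 19.5 percentage points higher from compound 1 to compound 2 (beyond the scatter), concerns the fluorine position on the pyridine ring and is modest in size.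

Compound 4 `O=C(NCC1CCC1)c1ccc(C#Cc2cccc(F)c2)cn1` arises from compound 3 by cyclobutylmethyl in place of 1,2,2-trimethylpropyl on an amide-type nitrogen. Among the compounds with values here, no measured step touches the amide nitrogen, so nothing among the measured compounds speaks directly to this change; the one measured step, at the aryl alkyne, does not bear on it. Compound 4 is therefore expected to show a step of a number 1.2 percentage points lower from compound 3 to compound 4 (within the scatter), that is, no change beyond the scatter, with wide uncertainty. Compound 4 is estimated at 30%, between 10% and 55%.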

Compound 4, largest response reached (reported as efficacy), in percent of the reference or control that the assay uses: 4.7%
Compound 4: the middle estimate sits 25.3 percentage points above what was measured, and the stated range ends above it.
By their numbers in this assay, from the lowest: compounds 4 and 1 (each within the scatter of the next); then compounds 3 and 2 (each within the scatter of the next).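

At the amide nitrogen, the exchange of 1,2,2-trimethylpropyl for cyclobutylmethyl gives, in this assay, a number 26.5 percentage points lower from compound 3 to compound 4 (beyond the scatter), which shows that the maximal response depends on this substituent even with the aryl alkyne held constant. The change is not a single feature: the substituent entering has one heavy atom fewer, carries a four-membered ring of carbon only, and lacks the defined stereocentre of the one leaving, and this one step cannot separate these differences. Nothing available accounts for the result.

On these data alone, it remains open whether the same exchange would give a step of similar size on the fluoropyridine alkynes of compound 1 and compound 2. As far as these compounds go, how an open-chain n-butyl group or a cyclopentylmethyl group on the amide nitrogen would read in this assay also remains open.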